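The source may hold more compounds than are shown below. What is called first, only, known or untested is meant among the compounds shown, and "the series" means these compounds.

Compound 1 `CCC(C)N(C(C)CC)S(=O)(=O)c1ccc(NC(=O)C(C)(O)C(F)(F)F)cc1` and compound 2 `CC(O)(C(=O)Nc1ccc(S(N)(=O)=O)cc1)C(F)(F)F` share one core and differ only at the sulfonyl sulfur. In an assay on a protein complex (Cavia porcellus) with sulfonylurea receptors; K-ATP channels (Homo sapiens) as the target (a higher number here means a weaker inhibitor, a lower number a stronger inhibitor), compound 1 gives > 30000 nM, a limit of the assay rather than a number. Among the compounds with values here, compound 2 gives 12800 nM, the only plain number in the set so far. The step of an at least 2.3-fold lower number from compound 1 to compound 2 (0.36 log units; beyond the scatter) is read against (the limit of > 30000 nM in this assay, at which 1 of the 2 values shown sits). Compound 3 `CCCN(CCC)S(=O)(=O)c1ccc(NC(=O)C(C)(O)C(F)(F)F)cc1` is the next member: dipropylamino in place of amino on a sulfonyl sulfur. Within the data shown here, this runs the one measured step backwards, so a weaker inhibitor is expected, possibly again reported only as a limit. Compound 3 is estimated at 30000 nM, between 12000 nM and 80000 nM, which would mean a step of a 2.3-fold higher number from compound 2 to compound 3 (0.37 log units; beyond the scatter).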

Compound 3, half-maximal inhibitory concentration: 6440 nM
The estimate for compound 3 lay 4.7-fold (0.67 log units) above the measured number, outside the stated range (below it).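

On the sulfonyl sulfur, this assay does not separate dipropylamino from amino: the result is a 2.0-fold lower number from compound 2 to compound 3 (0.30 log units; within the scatter). Replacing amino with a dialkylamino group therefore does not by itself weaken inhibition, and the two dialkylamino groups do differ, with an at least 4.6-fold lower number from compound 1 to compound 3 (0.66 log units; beyond the scatter). The size of that second step stays open-ended, as the value for compound 1 is a limit of the assay and not a number: the limit of > 30000 nM in this assay, at which 1 of the 3 values shown sits.

Open, going by these compounds, is whether dimethylamino, a longer chain such as dibutylamino, or a cyclic amine such as piperidine on this sulfur would read like compound 3 or like compound 1.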